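This account rests on a few compounds, and the source may have more. Where it says the series, first, only, none or still open, it means among the compounds named here.

Within the data shown here, compound 2 `COC(=O)c1ccc(-c2nnn(CC(=O)C(C)Oc3ccc(Oc4ccc(Cl)cc4)cc3)n2)cc1` stands as the higher of the two compounds measured so far: in a physicochemical assay for lipophilicity, read by HPLC, tested at 5 mM (a lower number here means a more polar compound, a higher number a more lipophilic compound), compound 2 gives 6.1, while compound 1 `CC(Oc1ccc(-c2ccccc2)cc1)C(=O)Cn1nnc(-c2ccccc2)n1` gives 5.3 in this assay, a gap beyond the usual scatter. Compound 3 `COC(=O)c1ccc(-c2nnn(CC(=O)C(C)Oc3ccc(-c4ccccc4)cc3)n2)cc1` has not yet been measured. It differs from compound 2 in one place: phenyl in place of 4-chlorophenoxy on an aromatic carbon. Among the measured compounds shown here, no measured pair shows this exchange, so the expectation rests on the change alone: a moderate drop beyond the scatter is expected, with the step of a number 0.60 log units lower from compound 2 to compound 3 (beyond the scatter) pointing downward. Compound 3 is therefore estimated at 5.5 in this assay, with a likely range from 5 to 6.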

Compound 3, partition coefficient: 5.4
The estimate for compound 3 lay 0.10 log units above the measured number; measured number inside the range.
By their numbers in this assay, from the lowest: compounds 1 and 3 (each within the scatter of the next); then compound 2.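

Among these compounds, exchanging 4-chlorophenoxy for phenyl on this aromatic carbon moves the number in this assay by a step beyond the scatter (a number 0.70 log units lower from compound 2 to compound 3 (beyond the scatter)), the first single-place change here to do so. Methoxycarbonyl in place of hydrogen on an aromatic carbon, by contrast, stays within the scatter (a number 0.10 log units higher from compound 1 to compound 3 (within the scatter)). The group at the first place therefore matters more in this series than the second change does.

Whether the oxygen or the chlorine accounts for the step stays open, a question that phenoxy or 4-chlorophenyl at this place would address. Nothing shown gives a reason for either step.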